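Aryl Swap on the Piperazine Nitrogen of Compound 2

The compounds below may be only part of what the source reports. "The series", "measured", "known", "first", "only" and "open" are said of these compounds alone.

Measured compounds:
compound 1 `CCCn1c(=O)[nH]c2nc(-c3ccc(S(=O)(=O)N4CCN(C)CC4)cc3)[nH]c2c1=O`: 48.2 nM
compound 2 `CCCn1c(=O)[nH]c2nc(-c3ccc(S(=O)(=O)N4CCN(c5ccccc5F)CC4)cc3)[nH]c2c1=O`: 3.22 nM

In an assay on CHO cells for displacement of a labelled ligand from adenosine receptor A2b (Homo sapiens), read by scintillation counting, with a stated time of 75 min, in the presence of a further agent that is not named here (a lower number here means a stronger inhibitor, a higher number a weaker inhibitor), compound 1 gives 48.2 nM and compound 2 gives 3.22 nM. Compound 2 therefore holds the lowest number of the two; its nearest neighbour is compound 1, and the step of a 15-fold lower number from compound 1 to compound 2 (1.18 log units; beyond the scatter) is the only one measured and is large, well beyond the scatter.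

Compound 3 `CCCn1c(=O)[nH]c2nc(-c3ccc(S(=O)(=O)N4CCN(c5ccc(C)cc5)CC4)cc3)[nH]c2c1=O` is the next compound. Its change from compound 2 is 4-methylphenyl in place of 2-fluorophenyl on an amine nitrogen in a ring. Within the data shown here, no measured step bears on this change directly: the one step known, a 15-fold lower number from compound 1 to compound 2 (1.18 log units; beyond the scatter), replaces a methyl by an aryl ring on the same nitrogen, whereas compound 3 keeps an aryl ring there and alters only the substituent on it. From that, the author expects a step of a 1.2-fold higher number from compound 2 to compound 3 (0.09 log units; within the scatter) from compound 2 to compound 3, that is, no change beyond the scatter in either direction. Compound 3 is expected to give about 4 nM in this assay, with a range from 1.5 nM to 12 nM.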

Compound 3, inhibition constant: 0.706 nM
Beside the measured number, compound 3's estimate is 5.7-fold (0.75 log units) above it; the whole stated range lies above it.
By their numbers in this assay, from the lowest: compound 3; then compound 2; then compound 1.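

In this assay, the aryl ring on this amine nitrogen is not interchangeable: keeping a ring there and exchanging 2-fluorophenyl for 4-methylphenyl, with the same count of heavy atoms on each side, still gives a 4.6-fold lower number from compound 2 to compound 3 (0.66 log units; beyond the scatter) and so adds a modest step beyond the scatter. Among these compounds, the earlier compounds showed the effect of only one aryl group in place of methyl, whereas 4-methylphenyl now gives a 68-fold lower number from compound 1 to compound 3 (1.83 log units; beyond the scatter) and goes further than the earlier 15-fold lower number from compound 1 to compound 2 (1.18 log units; beyond the scatter) in the same direction, leaving compound 3 with the lowest number of the three. No supporting measurement accounts for the difference between the two aryl groups.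

The groups 2-fluorophenyl and 4-methylphenyl differ both in the substituent and in where it stands on the ring, so the compounds shown do not separate these two changes. Also open, from the compounds shown here alone, is how an unsubstituted phenyl, a benzyl group, or a phenyl ring carrying chlorine or methoxy would compare on the same nitrogen.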